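This account rests on a few compounds, and the source may have more. Where it says the series, first, only, none or still open, it means among the compounds named here.

Compound 2 `COc1ccc(Oc2ccc(N3CC(=O)N([C@@H](CC(C)C)c4nc5ccc(C(=O)O)cc5n4C)C3=O)cc2)cc1` gives the lowest of the three numbers in an assay on isolated protein for inhibition of Bile acid receptor (Homo sapiens), read by TR-FRET and LanthaScreen (on this read-out lower numbers stand for stronger inhibition and higher numbers for weaker inhibition), where compound 2 reaches 75300 nM. Compound 1 `CC[C@@H](c1nc2ccc(C(=O)O)cc2n1C)N1C(=O)CN(c2ccc(Oc3ccccc3)cc2)C1=O` gives 210000 nM in this assay, and compound 3 `CC(C)[C@@H](c1nc2ccc(C(=O)O)cc2n1C)N1C(=O)CN(c2ccc(Oc3ccccc3)cc2)C1=O` gives 175000 nM in this assay; both of those stand beyond the scatter above compound 2. Among the measured compounds shown here, the only measured step between close neighbours is a 1.2-fold lower number from compound 1 to compound 3 (0.08 log units; within the scatter), and it concerns the chain next to the core rather than the group on the ether oxygen, so it does not bear on the change considered here. Compound 4 `CC(C)C[C@@H](c1nc2ccc(C(=O)O)cc2n1C)N1C(=O)CN(c2ccc(OC3CCCCC3)cc2)C1=O` differs from compound 2 by cyclohexyl in place of 4-methoxyphenyl on an oxygen on an aromatic ring. For the measured compounds named here, no measured pair isolates this replacement, and compound 2 differs from compounds 1 and 3 in two places at once, so the numbers give no direct guide. The step from compound 2 is therefore expected to be small, a 1.3-fold higher number from compound 2 to compound 4 (0.12 log units; within the scatter), with a slight lean toward a higher number. Compound 4 is expected to give about 100000 nM in this assay, within a range from 40000 nM to 300000 nM.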

Compound 4, half-maximal inhibitory concentration: 126000 nM
For compound 4 the middle estimate is 1.3-fold (0.10 log units) below the measured one; the measured number falls inside the stated range.
By their numbers in this assay, from the lowest: compounds 2, 4, 3 and 1 (each within the scatter of the next, the first and the last beyond it).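

In this assay, the replacement of 4-methoxyphenyl by cyclohexyl on an oxygen on an aromatic ring gives a 1.7-fold higher number from compound 2 to compound 4 (0.22 log units; within the scatter) and is the only pair shown that isolates a change at this position. At this place, then, a non-aromatic ring of carbon only can stand in for the aromatic ring with its methoxy group, and the two numbers remain within the scatter of each other. Nothing available explains this outcome. As far as these compounds go, it remains open whether a piperidine ring, a carboxylic acid or a short ethyl chain on this oxygen would move the number beyond the scatter. From the compounds shown here alone, it is also open whether the same replacement would read alike on compounds carrying a shorter chain on the other side of the shared core.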